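Swapping methyl for hydrogen on a phenolic oxygen

The source may hold more compounds than are shown below. What is called first, only, known or untested is meant among the compounds shown, and "the series" means these compounds.

Compound 1 `COc1ccc(C(=O)NNC(=O)/C=C/c2ccc(O)cc2)cc1` and compound 2 `O=C(/C=C/c1ccc(O)cc1)NNC(=O)c1ccc(O)cc1` share one core and differ in a single spot: hydrogen in place of methyl on an oxygen on an aromatic ring. In a functional assay on NCI-H1299 cells (Homo sapiens) for antiproliferative activity, read by MTT assay, with a stated time of 24 h (a higher number here means a weaker inhibitor, a lower number a stronger inhibitor), compound 1 gives 6640 nM, and compound 2 gives 5470 nM, which amounts to a 1.2-fold lower number from compound 1 to compound 2 (0.08 log units; within the scatter). Compound 3 `COc1cc(/C=C/C(=O)NNC(=O)c2ccccc2)ccc1O` is built from the same atoms as compound 1 joined differently; the difference between the two cores is not broken down here. In this assay compound 3 gives 6160 nM. Compound 4 `O=C(/C=C/c1ccc(O)c(O)c1)NNC(=O)c1ccccc1` has not yet been measured; it is related to compound 3 by the same change as before, (hydrogen in place of methyl on an oxygen on an aromatic ring). Because the measured change was a 1.2-fold lower number from compound 1 to compound 2 (0.08 log units; within the scatter), the expected step is similarly small, a 1.1-fold lower number from compound 3 to compound 4 (0.05 log units; within the scatter). Compound 4 is therefore estimated at 5500 nM, most likely between 2800 nM and 11000 nM.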

Compound 4, half-maximal inhibitory concentration: 6770 nM
For compound 4 the middle estimate is 1.2-fold (0.09 log units) below the measured one, and the stated range covers the measured number.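

Replacing methoxy with hydroxy on the core of compound 3 gives a 1.1-fold higher number from compound 3 to compound 4 (0.04 log units; within the scatter) in this assay, so the step is as small here as on the core of compound 1. Set side by side, the two steps do not differ: the same change on two cores in this assay, a 1.2-fold lower number (0.08 log units; within the scatter) from compound 1 to compound 2 and a 1.1-fold higher number (0.04 log units; within the scatter) from compound 3 to compound 4, 1.3-fold (0.13 log units) apart, within the scatter of two such steps. The change therefore carries over between these two cores without a detectable shift in the number, but each step lies within the scatter, so this shows no real effect of the change and nothing about other cores.

The compounds shown hold only methoxy or hydroxy at this spot on the aromatic ring. On these data alone, it stays open what an amine in that spot, or a longer chain in place of the methyl, would do.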